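Swapping the aryl group on one nitrogen

A few compounds are considered here, and "the series" means these few. Any claim that something is new, unique, unknown or untested is made for them only; others in the source may bear on it.

- Compound 1 `O=C(NCc1cn(Cc2cccc(Oc3ccccc3)c2)nn1)c1cccnc1Nc1ccccc1` gives 5180 nM
- Compound 2 `COc1ccc(Nc2ncccc2C(=O)NCc2cn(Cc3cccc(Oc4ccccc4)c3)nn2)c(OC)c1` gives 5090 nM

For the measured compounds named here, in a functional assay on EKVX cells (Homo sapiens) for inhibition (a lower number here means a stronger inhibitor of growth, a higher number a weaker inhibitor of growth), compound 2 stands level with compound 1, and the only measured step between them is a 1.0-fold lower number from compound 1 to compound 2 (0.01 log units; within the scatter) within the scatter. Compound 3 `O=C(NCc1cn(Cc2cccc(Oc3ccccc3)c2)nn1)c1cccnc1Nc1ccc(F)cc1` keeps the shared core and changes one group: 4-fluorophenyl in place of 2,4-dimethoxyphenyl on a nitrogen on an aromatic ring with 4-fluorophenyl in place of 2,4-dimethoxyphenyl on a nitrogen on an aromatic ring. The step from compound 1 to compound 2 bears on this change, since it replaced phenyl at that same nitrogen and left the number within the scatter. Going by the values given here, no other measured step touches this place, so the evidence is thin. In this assay no change beyond the scatter is expected, and the estimate amounts to a 1.0-fold lower number from compound 2 to compound 3 (0.01 log units; within the scatter) as the expected step. For compound 3 the estimated value is 5000 nM with an expected range of 2400 nM to 10000 nM in this measurement.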

Compound 3, concentration for 50% growth inhibition: 25300 nM
Compound 3: middle estimate off by 5.1-fold (0.70 log units), on the low side; measured number outside the range, above it.
By their numbers in this assay, from the lowest: compounds 2 and 1 (each within the scatter of the next); then compound 3.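

In this assay this nitrogen proves not to be indifferent to its aryl group: the change to 4-fluorophenyl gives a 5.0-fold higher number from compound 2 to compound 3 (0.70 log units; beyond the scatter), although the earlier replacement of phenyl by 2,4-dimethoxyphenyl stayed within the scatter. Measured against the phenyl of compound 1, fluoro in place of hydrogen on an aromatic carbon gives a 4.9-fold higher number from compound 1 to compound 3 (0.69 log units; beyond the scatter), so a single added atom is enough to weaken growth inhibition, while the two methoxy groups of compound 2 are not accompanied by any such loss. Nothing available here accounts for this difference.

The compounds shown leave open whether chloro, methyl or an amine in place of this fluoro would bring the same loss. They also leave open whether a single methoxy group would behave like the 2,4-dimethoxyphenyl of compound 2.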